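The source may hold more compounds than are shown below. What is called first, only, known or untested is meant among the compounds shown, and "the series" means these compounds.

Among the compounds with values here, compound 2 `O=C(Nc1ccc(Oc2ccnc3[nH]ccc23)c(F)c1)c1cc(-c2ccc(C(F)(F)F)cc2)ncn1` stands with the higher of the two numbers so far in a functional assay on PC-3 cells (Homo sapiens) for cytotoxicity, read by MTT assay, with a stated time of 72 h; a lower number here means a stronger inhibitor, a higher number a weaker inhibitor: compound 2 gives 4120 nM, whereas its nearest neighbour, compound 1 `O=C(Nc1ccc(Oc2ccnc3[nH]ccc23)c(F)c1)c1cc(-c2ccccc2)ncn1`, gives 40 nM in this assay. Within the data shown here, the single measured step, a 100-fold higher number from compound 1 to compound 2 (2.01 log units; beyond the scatter), is the only one that bears on the change now at hand.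

Compound 3 `O=C(Nc1ccc(Oc2ccnc3[nH]ccc23)c(F)c1)c1cc(-c2ccc(Br)cc2)ncn1` differs from compound 2 in one place: bromo in place of trifluoromethyl on an aromatic carbon, on an aromatic carbon of a six-membered aromatic ring of carbon only, para to a large group. Among the measured compounds shown here, no measured step joins a bromo and a trifluoromethyl at this position directly. What is known is that the position itself carries great weight, because a 100-fold higher number from compound 1 to compound 2 (2.01 log units; beyond the scatter) moved this assay a long way when a substituent entered there. Bromo is a different group from trifluoromethyl, so compound 3 is expected to land between the two measured compounds rather than at either end, with the step from compound 2 estimated as a 6.9-fold lower number from compound 2 to compound 3 (0.84 log units; beyond the scatter). For compound 3 the estimate in this assay is 600 nM, within a range of 90 nM to 3500 nM.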

Compound 3, half-maximal inhibitory concentration: 11300 nM
Compound 3: the middle estimate sits 19-fold (1.27 log units) below what was measured; measured number outside the range, above it.
By their numbers in this assay, from the lowest: compound 1; then compound 2; then compound 3.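

Both groups on the aromatic carbon para to a large group raise the number in this assay, and the bromo step, a 280-fold higher number from compound 1 to compound 3 (2.45 log units; beyond the scatter), is of the same large order as the trifluoromethyl step, a 100-fold higher number from compound 1 to compound 2 (2.01 log units; beyond the scatter), so among these three compounds the hydrogen of compound 1 gives the lowest number. Exchanging one substituent for the other does not recover that loss: with a single heavy atom entering where four leave, the smaller group goes the other way, a 2.7-fold higher number from compound 2 to compound 3 (0.44 log units; beyond the scatter), a modest step beside the two from compound 1, so heavy-atom count does not track the number across compound 2 and compound 3, and most of the change here comes with replacing hydrogen rather than with the choice between these two groups. Nothing measured on these compounds accounts for the order that they take.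

Whether every group at this place raises the number this far remains open, since the only two substituents shown are bromo and trifluoromethyl. A fluorine, a methoxy group, an amine or a carboxylic acid on the same carbon could show whether any substituent there keeps the number close to that of compound 1.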